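This account rests on a few compounds, and the source may have more. Where it says the series, first, only, none or still open, it means among the compounds named here.

Measured compounds:
Compound 1, `Cc1ccc(C(=O)NC2CCCCCC2)c(=O)n1Cc1ccc(F)cc1`: > 10000 nM in an assay on U-937 cells for inhibition of Fatty-acid amide hydrolase 1 (Homo sapiens), read by scintillation counting, with a stated time of 15 min; on this read-out higher numbers stand for weaker inhibition and lower numbers for stronger inhibition
Compound 2, `Cc1c(-c2ccc(F)cc2)cc(C(=O)NC2CCCCCC2)c(=O)n1Cc1ccc(F)cc1`: 530 nM in this assay
Compound 3, `Cc1c(F)cc(C(=O)NC2CCCCCC2)c(=O)n1Cc1ccc(F)cc1`: > 10000 nM in this assay

Compound 3 stands at the limit of this assay, with > 10000 nM, so no number is known for it. Compound 1 sits at the same limit, with > 10000 nM in this assay. Compound 2 gives 530 nM in this assay. Compound 4, `Cc1c(-c2ccccc2)cc(C(=O)NC2CCCCCC2)c(=O)n1Cc1ccc(F)cc1`, is not yet measured; it differs from compound 3 by phenyl in place of fluoro on an aromatic carbon.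

Among the measured compounds shown here, two measured steps bear on this change. From compound 1 to compound 2 a 4-fluorophenyl in place of hydrogen gave an at least 18-fold lower number from compound 1 to compound 2 (1.27 log units; beyond the scatter), and from compound 2 to compound 3 a fluoro in place of 4-fluorophenyl gave an at least 18-fold higher number from compound 2 to compound 3 (1.27 log units; beyond the scatter). The step from compound 1 to compound 3 is a step that the two limits leave unreadable from compound 1 to compound 3. Compound 4 carries a phenyl at the position where compound 2 carries the 4-fluorophenyl, so compound 4 is expected to land near compound 2, with an at least 14-fold lower number from compound 3 to compound 4 (1.15 log units; beyond the scatter). Compound 4 is estimated at 700 nM, between 250 nM and 2500 nM.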

Compound 4, half-maximal inhibitory concentration: 560 nM
Estimate against measurement, compound 4: 1.3-fold (0.10 log units) above; the range from low to high includes it.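

A plain phenyl at this position, carrying no fluoro of its own, is enough to move the compound off the limit in this assay: it gives an at least 17-fold lower number from compound 3 to compound 4 (1.25 log units; beyond the scatter), and in place of hydrogen it gives an at least 17-fold lower number from compound 1 to compound 4 (1.25 log units; beyond the scatter). The fluoro of the 4-fluorophenyl group is not needed to reach this level, as the comparison shows a 1.1-fold higher number from compound 2 to compound 4 (0.02 log units; within the scatter). Both large steps start from a limit and not from a number: the limit of > 10000 nM in this assay, at which 2 of the 4 values shown sit.

The compounds shown leave open whether an aromatic ring is needed here at all, or whether a cyclohexyl ring or a butyl chain at this position would serve as well. They also leave open how an amine or a carboxylic acid on the phenyl would read in this assay.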